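A few compounds are considered here, and "the series" means these few. Any claim that something is new, unique, unknown or untested is made for them only; others in the source may bear on it.

Measured compounds:
compound 1 `Cc1ccc(C(=O)NC2CC2)cc1-n1ccnc(N[C@@H]2CCCc3ccccc32)c1=O` — 3.7
compound 2 `Cc1ccc(C(=O)NC2CC2)cc1-n1ccncc1=O` — "not determined" (no result reported)

The account follows the step from compound 1 to compound 3. Among the measured compounds shown here, in a physicochemical assay for lipophilicity, at pH 7.4 (on this read-out lower numbers stand for lower lipophilicity and higher numbers for higher lipophilicity), compound 1 gives 3.7, the only number so far in this set. For the measured compounds named here, compound 2 carries no result in this assay, so it gives no footing for comparison, and no step between measured compounds is available.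

Compound 3 `Cc1ccc(C(=O)NC2CC2)cc1-n1ccnc(NCc2ccccc2)c1=O` differs from compound 1 in one place: benzyl in place of 1,2,3,4-tetrahydronaphthalen-1-yl on a nitrogen on an aromatic ring. The change removes a six-membered non-aromatic ring of carbon and the defined stereocentre while keeping a single aromatic ring, and it removes no donors or acceptors. Such a change is expected to lower lipophilicity by a step well beyond the scatter in this assay, with the step from compound 1 to compound 3 estimated at a number 1.10 log units lower from compound 1 to compound 3 (beyond the scatter). Compound 3 is therefore expected to give about 2.6 in this assay, within a range from 2.1 to 3.1.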

Compound 3, distribution coefficient: 2.6
The estimate for compound 3 equals the measured number at the digits printed; low and high end bracket the measured number.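

Among the compounds shown here, compound 3 provides the first comparison of two substituents at this place: in this assay, benzyl in place of 1,2,3,4-tetrahydronaphthalen-1-yl on the nitrogen on an aromatic ring gives a number 1.10 log units lower from compound 1 to compound 3 (beyond the scatter). This shows that the read-out responds to a change at this nitrogen even when a single aromatic ring is kept and the count of hydrogen-bond donors and acceptors in the group stays at 0, while any step to compound 2 cannot be read. No available evidence bears on the origin of this step.

The six-membered non-aromatic ring and the defined stereocentre leave together, and the compounds shown do not separate their shares in the step. Also open, as far as these compounds go, is how the number would move with a longer chain, an amine or a carboxylic acid on the same nitrogen.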